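A few compounds are considered here, and "the series" means these few. Any claim that something is new, unique, unknown or untested is made for them only; others in the source may bear on it.

Measured so far: compound 1 `CN(Cc1cn2c(N3CCN4CCCC4C3)cccc2n1)[C@H]1CCCc2cccnc21` gives 3900 nM in an ADME assay on HOS cells (Homo sapiens) for cytotoxicity; on this read-out higher numbers stand for lower toxicity in this test and lower numbers for higher toxicity in this test. Compound 2 `CN1CCN(c2cccc3nc(CN(Cc4ccccc4)[C@H]4CCCc5cccnc54)cn23)CC1` gives 9300 nM in this assay. Compound 3 `CN1CCN(c2cccc3nc(CN(C)[C@H]4CCCc5cccnc54)[nH]c23)CC1` reports only a limit, > 5000 nM in this assay, and this is the limit of > 5000 nM in this assay, at which 1 of the 3 values shown sits.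

Compound 1 stands lowest of the two numbers; compound 2 lies above it by a gap beyond the usual scatter. Compound 3 contributes a limit, not a number, so it cannot be ranked.

Compound 4 `CNCCN(C)c1cccc2nc(CN(C)[C@H]3CCCc4cccnc43)cn12` differs from compound 1 by a group of 6 heavy atoms (4 carbon, 2 nitrogen; no ring) in place of a group of 9 heavy atoms (7 carbon, 2 nitrogen; one five-membered non-aromatic ring with 1 hetero atom, one six-membered non-aromatic ring with 2 hetero atoms), on an aromatic carbon. Among the measured compounds shown here, no measured pair shows this change, so the expectation rests on compound 1 alone with wide uncertainty. A modest rise in the number, toward lower toxicity, is expected: the estimated step is a 1.5-fold higher number from compound 1 to compound 4 (0.19 log units; within the scatter). Compound 4 is expected near 6000 nM, within 2000 nM to 18000 nM.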

Compound 4, half-maximal cytotoxic concentration: 2200 nM
The estimate for compound 4 lay 2.7-fold (0.44 log units) above the measured number; low and high end bracket the measured number.
By their numbers in this assay, from the lowest: compounds 4 and 1 (each within the scatter of the next); then compound 2.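

Among the compounds shown here, this is the first one-place step: in this assay, replacing the fused bicyclic amine of compound 1 with methyl(2-(methylamino)ethyl)amino on the aromatic carbon next to the ring nitrogen gives a 1.8-fold lower number from compound 1 to compound 4 (0.25 log units; within the scatter). The open chain and the two-ring group therefore cannot be told apart on this read-out at this position. No measurement shown accounts for the size of this step. On these data alone, whether a carboxylic acid, an amide or a longer chain at this carbon would move the number beyond the scatter remains open.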